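The source may report more compounds than this note shows. Statements on the series, on what has been measured and on what is new or still open speak of the compounds shown alone.

compound 1 `CSc1ncnc2c1c(-c1ccoc1)cn2[C@@H]1O[C@H](CO)[C@@H](O)[C@H]1O`: > 100000 nM (a limit)
compound 2 `C#Cc1cn([C@@H]2O[C@H](CO)[C@@H](O)[C@H]2O)c2ncnc(SC)c12`: > 100000 nM (a limit)

In an ADME assay on MRC5 cells (Homo sapiens), read by MTT assay, with a stated time of 72 h (on this read-out higher numbers stand for weaker inhibition and lower numbers for stronger inhibition), compound 1 stands at > 100000 nM as a limit and not as a number. Compound 2 gives > 100000 nM as a limit too. Going by the values given here, the series so far therefore rests on the limit of > 100000 nM in this assay, at which 2 of the 2 values shown sit, alone. Among the compounds with values here, the one measured step, a step that the two limits leave unreadable from compound 1 to compound 2 for ethynyl in place of furan-3-yl on an aromatic carbon, offers no size to carry over.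

Compound 3 `CNc1ncnc2c1c(-c1ccoc1)cn2[C@@H]1O[C@H](CO)[C@@H](O)[C@H]1O` keeps the furan-3-yl group of compound 1 and has methylamino in place of methylsulfanyl on an aromatic carbon. Within the data shown here, no measured step covers this change, so no step beyond the scatter is expected in this assay for compound 3. The expected step is an at least 1.4-fold lower number from compound 1 to compound 3 (0.15 log units; that floor lies within the scatter) by this estimate. For compound 3 the estimated value is 70000 nM with an expected range from 10000 nM to 100000 nM in this assay.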

Compound 3, half-maximal inhibitory concentration: > 100000 nM
Compound 3 ended at the assay's limit; the forecaster's own chance of this, stated with the estimate: 60%; middle value at least 1.4-fold (0.15 log units) from the limit.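

No step can be read from compound 1 to compound 3, since both stand only as limits in this assay: the limit of > 100000 nM in this assay, at which 3 of the 3 values shown sit. The compounds shown leave open how far each lies beyond that limit, and whether any change on the shared core gives a readable number.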